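This account rests on a few compounds, and the source may have more. Where it says the series, first, only, none or still open, it means among the compounds named here.

Measured so far:

compound 1, `Cc1ccc2nc(Nc3nc(Nc4ccc(S(C)(=O)=O)cc4)ncc3F)sc2c1`: 14300 nM
compound 2, `COc1ccc2nc(Nc3nc(Nc4ccc(S(N)(=O)=O)cc4)ncc3F)sc2c1`: 26600 nM
compound 3, `Cc1ccc2nc(Nc3ccnc(Nc4ccc(S(C)(=O)=O)cc4)n3)sc2c1`: 4440 nM

All three numbers come from a functional assay on MDA-MB-231 cells (Homo sapiens) for antiproliferative activity, read by MTT assay, with a stated time of 48 h; on this read-out lower numbers stand for stronger inhibition and higher numbers for weaker inhibition. Compound 3 differs from compound 1 in one place, (hydrogen in place of fluoro on an aromatic carbon), and that change gave a 3.2-fold lower number from compound 1 to compound 3 (0.51 log units; beyond the scatter). Compound 2 differs from compound 1 in more than one place; the difference between the two cores is not broken down here. Its value sits close to that of compound 1 and above that of compound 3.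

Compound 4, `COc1ccc2nc(Nc3ccnc(Nc4ccc(S(N)(=O)=O)cc4)n3)sc2c1`, is not yet measured. It stands to compound 2 exactly as compound 3 stands to compound 1: hydrogen in place of fluoro on an aromatic carbon. Since this is the same change at the same place, a step of similar size is expected in this assay, a 3.1-fold lower number from compound 2 to compound 4 (0.50 log units; beyond the scatter), resting on a 3.2-fold lower number from compound 1 to compound 3 (0.51 log units; beyond the scatter). Compound 4 is therefore estimated at 8500 nM, expected to fall between 3500 nM and 20000 nM.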

Compound 4, half-maximal inhibitory concentration: 6240 nM
Compound 4: the middle estimate sits 1.4-fold (0.13 log units) above what was measured; the range from low to high includes it.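

In this assay, placing hydrogen where the fluoro group stood gave a 4.3-fold lower number from compound 2 to compound 4 (0.63 log units; beyond the scatter). Set beside the earlier case, the change carried from one core to the other with a similar size: the same change on two cores in this assay, a 3.2-fold lower number (0.51 log units; beyond the scatter) from compound 1 to compound 3 and a 4.3-fold lower number (0.63 log units; beyond the scatter) from compound 2 to compound 4, 1.3-fold (0.12 log units) apart, within the scatter of two such steps These two pairs do not show that the step would hold on any further core, and they do not explain why the compounds with hydrogen give the lower numbers.

The compounds shown carry only fluoro or hydrogen on this aromatic carbon, leaving open what chloro, a methyl group or an amine would do there. From the compounds shown here alone, how the methoxy and sulfonamide groups of compound 2 each act on their own also stays open.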